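The source may report more compounds than this note shows. Statements on the series, on what has been measured and on what is new or still open speak of the compounds shown alone.

In a functional assay on KB-V1 cells (Homo sapiens) for cytotoxicity, read by MTT assay, with a stated time of 72 h (a lower number here means a stronger inhibitor, a higher number a weaker inhibitor), compound 1 (`O=C1Nc2ccccc2/C1=N/NC(=S)Nc1ccccc1`) gives 1470 nM, compound 2 (`CN(C)c1ccc(NC(=S)N/N=C2\C(=O)Nc3ccccc32)cc1`) gives 2320 nM and compound 3 (`O=C1Nc2ccccc2/C1=N/NC(=S)Nc1ccc(Oc2ccccc2)cc1`) gives 1670 nM. Compound 3 thus stands within the scatter of both other compounds, and the numbers do not separate the three.

The next compound to be tested, compound 4 (`O=C1Nc2ccccc2/C1=N/NC(=S)Nc1ccc(C(F)(F)F)cc1`), carries trifluoromethyl in place of phenoxy on an aromatic carbon, para to a large group: trifluoromethyl in place of phenoxy on an aromatic carbon. Among the compounds with values here, no measured compound yet carries trifluoromethyl, so the evidence is indirect.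

Within the data shown here, three measured steps bear on the change. Phenoxy in place of hydrogen gave a 1.1-fold higher number from compound 1 to compound 3 (0.06 log units; within the scatter), dimethylamino in place of hydrogen gave a 1.6-fold higher number from compound 1 to compound 2 (0.20 log units; within the scatter), and phenoxy in place of dimethylamino gave a 1.4-fold lower number from compound 2 to compound 3 (0.14 log units; within the scatter). All three lie within the scatter, so the two groups measured at this place have not yet shifted the number beyond it, although three compounds make a narrow basis.

No step beyond the scatter, in either direction, is therefore expected in this assay. The expected change is a 1.0-fold lower number from compound 3 to compound 4 (0.02 log units; within the scatter), a step estimated to stay within the scatter. The value estimated for compound 4 is 1600 nM, with an expected range of 850 nM to 3000 nM.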

Compound 4, half-maximal inhibitory concentration: 2100 nM
Estimate against measurement, compound 4: 1.3-fold (0.12 log units) below, within the range that was stated.
By their numbers in this assay, from the lowest: compounds 1, 3, 4 and 2 (each within the scatter of the next).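

In this assay, trifluoromethyl at this place, on an aromatic carbon of a six-membered aromatic ring of carbon only, para to a large group, leaves the number within the scatter of all three earlier compounds (a 1.3-fold higher number from compound 3 to compound 4 (0.10 log units; within the scatter); a 1.1-fold lower number from compound 2 to compound 4 (0.04 log units; within the scatter); a 1.4-fold higher number from compound 1 to compound 4 (0.15 log units; within the scatter)). The earlier compounds had shown this only for phenoxy and dimethylamino, and the new result extends it to a group with no ring and no hydrogen-bond acceptor, so losing the aromatic ring and the acceptor of phenoxy does not produce a step beyond the scatter among these four compounds. Nothing available explains why these steps stay so small.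

The compounds shown leave open whether any group at this place can move the number beyond the scatter, for instance a carboxylic acid, a primary amine or a longer alkyl chain. They also leave open whether trifluoromethyl or phenoxy would behave the same way on another carbon of this ring, or whether a change in the shared core would matter more than any of these replacements.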